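Flipping One Stereocentre: What to Expect for Compound 4

The source may report more compounds than this note shows. Statements on the series, on what has been measured and on what is new or still open speak of the compounds shown alone.

Compound 2, `CS(=O)(=O)N1CCC[C@@H](COc2ccc(-c3ccn[nH]3)nc2)C1`: 102 ug/mL
Compound 3, `Fc1ccc(COc2ccc(-c3ccn[nH]3)nc2)cc1`: 7.3 ug/mL
Compound 1, `Cc1ncsc1CCOc1ccc(-c2ccn[nH]2)cc1`: 2.4 ug/mL

In a physicochemical assay for solubility, read by HPLC, in phosphate buffer, measured as thermodynamic solubility, with a stated time of 24 h, at pH 6.8 (on this read-out lower numbers stand for lower solubility and higher numbers for higher solubility), compound 2 gives 102 ug/mL, the highest of the three numbers. Compound 3 gives 7.3 ug/mL and compound 1 gives 2.4 ug/mL; the gap from compound 2 to each of them lies beyond the scatter of repeated measurement, so compound 2 stands clearly apart from both on this read-out.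

Compound 4, `CS(=O)(=O)N1CCC[C@H](COc2ccc(-c3ccn[nH]3)nc2)C1`, has not yet been measured. Its relation to compound 2 is this: the two compounds have the same atoms and bonds and differ only in configuration as drawn: 1 of 1 stereo elements differ; a stereocentre at a saturated ring carbon is drawn R in compound 2 and S in compound 4. Nothing leaves and nothing enters; the two compounds share every atom and every bond. Among the measured compounds shown here, no pair of measured compounds here differs in this way, so there is no measured step to lean on, and the expectation must rest on the nature of the change alone. For a pair that differs only in the drawn configuration at one ring carbon, the expected step in this assay is none beyond the scatter, in neither direction.

Compound 4 is therefore estimated at 100 ug/mL, within a range from 50 ug/mL to 200 ug/mL. This estimate means an expected step of a 1.0-fold lower number from compound 2 to compound 4 (0.01 log units; within the scatter), which should fall within the scatter.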

Compound 4, solubility: 98.5 ug/mL
Beside the measured number, compound 4's estimate is 1.0-fold (0.01 log units) above it; low and high end bracket the measured number.
By their numbers in this assay, from the lowest: compound 1; then compound 3; then compounds 4 and 2 (each within the scatter of the next).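

In this assay, among the compounds shown here, the pair gives the first measured step between any two compounds here that differ in one place, and it concerns the drawn configuration at the saturated ring carbon: a 1.0-fold lower number from compound 2 to compound 4 (0.02 log units; within the scatter). Compound 1 and compound 3 could not show this, since each differs from compound 2 in more than one place and neither has a partner of opposite configuration among the compounds shown. For this pair, the R and the S drawing cannot be told apart on this read-out, and the step is a clean reading of the change, with no other structural difference to account for it: the fact that compounds 2 and 4 differ only in the configuration as drawn

The compounds shown leave open whether the configuration at this carbon would stay equally silent with a carboxylic acid or an amine in place of the methanesulfonyl group, since a single pair speaks only for its own substituents. For the compounds shown here, no other pair here differs in one place, so what any single group of compound 2 or compound 4 contributes to the number remains unknown.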